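Ester series at the urotensin receptor: halogen position shift

The compounds below may be only part of what the source reports. "The series", "measured", "known", "first", "only" and "open" are said of these compounds alone.

Measured so far:
- compound 1, `Cc1ccccc1C(=O)OC(CCN(C)C)c1ccc(Cl)cc1`, 126%
- compound 2, `Cc1cccc(C(=O)OC(CCN(C)C)c2ccc(Cl)cc2)c1C`, 91%
- compound 3, `Cc1c(Cl)cccc1C(=O)OC(CCN(C)C)c1ccc(Cl)cc1`, 118%

In an assay on NIH3T3 cells with Urotensin-2 receptor (Homo sapiens) as the target (a lower number here means a smaller maximal response, a higher number a larger maximal response), compound 3 stands second highest of the three numbers. Its nearest neighbour is compound 1, lying within the scatter (a number 8 percentage points lower from compound 1 to compound 3 (within the scatter)); the furthest is compound 2, lying beyond it (a number 27 percentage points higher from compound 2 to compound 3 (beyond the scatter)). The only large movement in the set is a number 35 percentage points lower from compound 1 to compound 2 (beyond the scatter).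

The next compound is compound 4, `Cc1cc(Br)ccc1C(=O)OC(CCN(C)C)c1ccc(Cl)cc1`. Relative to compound 3 the change is 4-bromo-2-methylphenyl in place of 3-chloro-2-methylphenyl on a carbonyl carbon.

Among the compounds with values here, no measured step covers this change directly. Within the data shown here, the steps that bear on it are a number 8 percentage points lower from compound 1 to compound 3 (within the scatter), showing that adding chlorine to the ring of compound 1 leaves the maximal response within the scatter, and a number 27 percentage points higher from compound 2 to compound 3 (beyond the scatter), showing a modest gain when chlorine replaces methyl. Compound 4 keeps the 2-methyl of compound 3 and carries a halogen on the same ring, only moved and changed from chlorine to bromine. Among the measured compounds shown here, the data give no step for that, so no step beyond the scatter is expected; the estimated change for compound 4 is a number 3 percentage points lower from compound 3 to compound 4 (within the scatter).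

The expected value for compound 4 in this assay is 115%, estimated within 92% to 138%.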

Compound 4, largest response reached (reported as efficacy), in percent of the reference or control that the assay uses: 95%
The estimate for compound 4 lay 20 percentage points above the measured number; low and high end bracket the measured number.
By their numbers in this assay, from the lowest: compounds 2 and 4 (each within the scatter of the next); then compounds 3 and 1 (each within the scatter of the next).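

In this assay, the exchange of 3-chloro-2-methylphenyl for 4-bromo-2-methylphenyl on a carbonyl carbon is not neutral: a number 23 percentage points lower from compound 3 to compound 4 (beyond the scatter), although both groups carry a single halogen and keep the 2-methyl. Compound 4 instead sits with the 2,3-dimethylphenyl ester, a number 4 percentage points higher from compound 2 to compound 4 (within the scatter), while a number 31 percentage points lower from compound 1 to compound 4 (beyond the scatter) shows that a bromo in place of hydrogen on the ring of compound 1 lowers the maximal response much as the methyl did in a number 35 percentage points lower from compound 1 to compound 2 (beyond the scatter), with compound 3 going against this pattern as the one ring addition that stays within the scatter of compound 1. No measurement available here accounts for the lower response of compound 4.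

On these data alone, the step from compound 3 to compound 4 changes both the halogen and its place, so it remains open which of the two goes with the lower response; chlorine at the place of the bromine in compound 4, or bromine at the place of the chlorine in compound 3, would separate them. Also open, as far as these compounds go, is how the maximal response would respond to a methoxy group or a nitrile at either ring place.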